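A few compounds are considered here, and "the series" means these few. Any claim that something is new, unique, unknown or untested is made for them only; others in the source may bear on it.

Compound 1 `CC1CCC(C[C@H](CC(=O)N2CCOCC2)C(=O)N[C@]2(C#N)CCN(C3CCCCC3)C2)CC1`: 13.8 nM
Compound 2 `N#CC1(NC(=O)[C@@H](CC(=O)N2CCOCC2)CC2CCCCC2)CC1`: 12 nM
Compound 3 `N#C[C@@]1(NC(=O)[C@@H](CC(=O)N2CCOCC2)CC2CCCCC2)CCNC1`: 123 nM

In an assay on isolated protein for inhibition of cathepsin S (Homo sapiens) (on this read-out higher numbers stand for weaker binding and lower numbers for tighter binding), compound 1 stands second highest of the three numbers; compound 2 lies within the scatter of it, while compound 3 sits beyond the scatter above both. Among the compounds with values here, the one measured step, a 10-fold higher number from compound 2 to compound 3 (1.01 log units; beyond the scatter), concerns the ring on the amide-type nitrogen and leaves the side chain untouched, so it does not bear on the change now at hand. Compound 4 `N#C[C@@]1(NC(=O)[C@@H](CC(=O)N2CCOCC2)CC2Cc3ccccc3C2)CCN(C2CCCCC2)C1` differs from compound 1 by 2,3-dihydro-1H-inden-2-yl in place of 4-methylcyclohexyl on a saturated chain carbon, two bonds along the chain from a carbonyl carbon. Within the data shown here, no measured step probes this position, so the expectation rests on compound 1 alone: the step of a 1.1-fold higher number from compound 1 to compound 4 (0.04 log units; within the scatter) is expected to stay within the scatter, with no clear direction. Compound 4 is therefore estimated at 15 nM, in a range from 5 nM to 45 nM.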

Compound 4, dissociation constant: 23.1 nM
Compound 4: the middle estimate sits 1.5-fold (0.19 log units) below what was measured, within the range that was stated.
By their numbers in this assay, from the lowest: compounds 2, 1 and 4 (each within the scatter of the next); then compound 3.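

In this assay, within the data shown here, the step of a 1.7-fold higher number from compound 1 to compound 4 (0.22 log units; within the scatter) gives the first reading at this position, on a saturated chain carbon, two bonds along the chain from a carbonyl carbon. It shows that 2,3-dihydro-1H-inden-2-yl, with its six-membered aromatic ring of carbon, can replace 4-methylcyclohexyl without a shift beyond the scatter. Nothing available explains this result.

Still open, from the compounds shown here alone, is whether a phenyl group or a piperidin-4-yl group, with its amine, would behave the same way at this position. Going by these compounds, it is also open whether the same exchange would hold with the 1-cyanocyclopropyl group of compound 2.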